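The source may report more compounds than this note shows. Statements on the series, on what has been measured and on what is new or still open speak of the compounds shown alone.

Measured compounds:
- compound 1, `CCCCCCCCCCNC(=N)NC(=N)Nc1ccccc1`: 5.43
- compound 2, `CCCCCCCCNC(=N)NC(=N)Nc1ccccc1`: 4.43
- compound 3, `CCCCCCS(=O)(=O)c1ccc(NC(=N)NC(=N)NCCCCCCNC(=N)NC(=N)Nc2ccc(S(=O)(=O)CCCCCC)cc2)cc1`: 5.1

In a physicochemical assay for lipophilicity, in phosphate buffer, measured as octanol-water partition, at pH 11.5 (a higher number here means a more lipophilic compound, a lower number a more polar compound), compound 2 stands lowest of the three numbers, with compound 3 the nearest above it and compound 1 the furthest. Compound 4, `CCCCCCCCNC(=N)NC(=N)Nc1ccc(OC)cc1`, differs from compound 2 by methoxy in place of hydrogen on an aromatic carbon. Among the measured compounds shown here, the only measured step, a number 1.00 log units lower from compound 1 to compound 2 (beyond the scatter), concerns a saturated chain and not the aromatic ring, so no measured step bears directly on this change. For the measured compounds named here, with no comparable step to draw on, the methoxy for hydrogen exchange is expected to move this assay little, if at all, so a step of a number 0.03 log units lower from compound 2 to compound 4 (within the scatter) is expected, within the scatter. Compound 4 is therefore estimated at 4.4, with a range from 4 to 4.8.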

Compound 4, partition coefficient: 4.41
Compound 4: the middle estimate sits 0.01 log units below what was measured; measured number inside the range.
By their numbers in this assay, from the lowest: compounds 4 and 2 (each within the scatter of the next); then compound 3; then compound 1.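

In this assay the exchange of hydrogen for methoxy on an aromatic carbon, para to a large group, gives a number 0.02 log units lower from compound 2 to compound 4 (within the scatter) and so leaves the two compounds indistinguishable. The earlier step of a number 1.00 log units lower from compound 1 to compound 2 (beyond the scatter) on the saturated chain lay beyond the scatter, while this first step on the aromatic ring does not. Nothing given here explains this result. As far as these compounds go, whether an amine or a carboxylic acid at this position would behave like methoxy remains open, as does whether methoxy would give the same result alongside the longer chain of compound 1.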